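The source may hold more compounds than are shown below. What is called first, only, known or untested is meant among the compounds shown, and "the series" means these compounds.

Compound 1 `Nc1cc(N)c2nc(-c3ccccc3)c(NCc3ccc(F)cc3)nc2c1` and compound 2 `COc1ccc(Sc2nc3cc(N)cc(N)c3nc2-c2ccccc2)cc1` share one core and differ at a single aromatic carbon. In a functional assay on KM12 cells (Homo sapiens) for inhibition, read by sulforhodamine B assay, with a stated time of 48 h (a lower number here means a stronger inhibitor of growth, a higher number a weaker inhibitor of growth), compound 1 gives 7410 nM. Compound 2 reaches only a limit in this assay, < 100000 nM, and that value is a limit of the assay rather than a number. Going by the values given here, the step that the limit leaves unreadable from compound 1 to compound 2 is therefore of unknown size, and the only evidence bearing on it is the limit of < 100000 nM in this assay, at which 1 of the 2 values shown sits. Compound 2 thus stands at a limit, so its place relative to compound 1 cannot be read from what is shown.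

Compound 3 `Nc1cc(N)c2nc(-c3ccccc3)c(Oc3ccc(F)cc3)nc2c1` arises from compound 2 by 4-fluorophenoxy in place of (4-methoxyphenyl)sulfanyl on an aromatic carbon. Among the compounds with values here, no measured step bears directly on this change; the one measured step, from compound 1 to compound 2, is unreadable and gives no size to carry over. The single number shown in this assay belongs to compound 1, and it sets the scale for any expectation. The estimate for compound 3 is 20000 nM, with a range from 4000 nM to 90000 nM. The step this estimate means is expected to be a step that the limit leaves unreadable from compound 2 to compound 3.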

Compound 3, concentration for total growth inhibition: 40700 nM
For compound 3 the middle estimate is 2.0-fold (0.31 log units) below the measured one; measured number inside the range.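

Going by these compounds alone, compound 3 gives the first readable step at this aromatic carbon next to the ring nitrogen: in this assay, 4-fluorophenoxy in place of (4-fluorobenzyl)amino gives a 5.5-fold higher number from compound 1 to compound 3 (0.74 log units; beyond the scatter). Since a higher number here means a weaker inhibitor of growth, the change from the amino-linked group to the oxygen-linked aryl group costs inhibition, and the substituent at this carbon is thus shown to matter to the read-out. The value of compound 2 is a limit and not a number, so neither step involving compound 2 can be read, and the sulfanyl group cannot be placed against the other two: the limit of < 100000 nM in this assay, at which 1 of the 3 values shown sits.

The step from compound 1 to compound 3 changes both the linking atom and the link to the aromatic ring, and it does not say which of these carries the difference. On these data alone, how a 4-fluorobenzyloxy group, a (4-fluorophenyl)amino group or a small group such as a plain amine or a carboxylic acid would stand at this carbon remains open.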